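Extending the Ester Chain of Compound 2

This account rests on a few compounds, and the source may have more. Where it says the series, first, only, none or still open, it means among the compounds named here.

Measured so far in a functional assay on the whole organism with Scenedesmus acutus as the target, with a stated time of 20 h; a higher number here means a weaker inhibitor, a lower number a stronger inhibitor:
compound 1, `CCOC(=O)c1cc(N2C(=O)C3=C(CCCC3)C2=O)c(F)cc1Cl`, gives 87.1 nM
compound 2, `CCOC(=O)c1cc(N2C(=O)C3=C(CCCC3)C2=O)ccc1Cl`, gives 2140 nM
compound 3, `CCCCOC(=O)c1cc(N2C(=O)C3=C(CCCC3)C2=O)c(F)cc1Cl`, gives 141 nM

Compound 2 stands at the highest number of the three in this assay. Going by the values given here, the single step that separates it from compound 1, a 25-fold higher number from compound 1 to compound 2 (1.39 log units; beyond the scatter), is the one large step in this set, and compound 2 also lies well above compound 3.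

Compound 4, `CCCCCOC(=O)c1cc(N2C(=O)C3=C(CCCC3)C2=O)ccc1Cl`, is compound 2 with one change: propyl in place of hydrogen on a saturated chain carbon, two bonds along the chain from an oxygen next to a carbonyl group. Among the compounds with values here, the one measured step that bears on this is the lengthening of the same chain between compound 1 and compound 3, a 1.6-fold higher number from compound 1 to compound 3 (0.21 log units; within the scatter). That step stayed within the scatter, so the account expects the longer chain in compound 4 to move the number only a little, if at all, with a 1.3-fold higher number from compound 2 to compound 4 (0.10 log units; within the scatter) as the expected step in this assay. Compound 4 is therefore estimated at 2700 nM in this assay, with a range from 1000 nM to 7000 nM.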

Compound 4, half-maximal inhibitory concentration: 5370 nM
Estimate against measurement, compound 4: 2.0-fold (0.30 log units) below; the range from low to high includes it.
By their numbers in this assay, from the lowest: compounds 1 and 3 (each within the scatter of the next); then compound 2; then compound 4.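

Compound 4 shows that, with hydrogen rather than fluoro on the aromatic carbon, extending this chain from ethoxy to pentyloxy changes the result in this assay, giving [ a 2.5-fold higher number from compound 2 to compound 4 (0.40 log units; beyond the scatter) ], a modest step beyond the scatter. The earlier chain step, [ a 1.6-fold higher number from compound 1 to compound 3 (0.21 log units; within the scatter) ], stayed within the scatter, but it added ethyl rather than propyl and had fluoro on the aromatic carbon, so the two steps differ in more than one way and do not separate these influences. Nothing measured here accounts for the step from ethoxy to pentyloxy.

The compounds shown leave open how the pentyloxy chain behaves with fluoro on the aromatic carbon. They also leave open whether a longer chain, such as hexyloxy, would continue this step, or how a carboxylic acid would compare at this place.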